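Swapping 4-methoxyphenyl for 3-fluorophenyl at compound 4

A few compounds are considered here, and "the series" means these few. Any claim that something is new, unique, unknown or untested is made for them only; others in the source may bear on it.

- Compound 1 `O=C(CSc1nnc(-c2ccncc2)o1)N/N=C/c1ccc(Cl)cc1` gives 20500 nM
- Compound 2 `O=C(CSc1nnc(-c2ccncc2)o1)N/N=C/c1ccc(Br)cc1` gives 24500 nM
- Compound 3 `COc1ccc(/C=N/NC(=O)CSc2nnc(-c3ccncc3)o2)cc1` gives 19800 nM

These three values come from a functional assay on BGC-823 cells (Homo sapiens) for cytotoxicity, read by MTT assay, with a stated time of 48 h; on this read-out lower numbers stand for stronger inhibition and higher numbers for weaker inhibition. Compound 3, at 19800 nM, lies within the usual scatter of both other compounds, so the three cannot be told apart.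

Compound 4 (`O=C(CSc1nnc(-c2ccncc2)o1)N/N=C/c1cccc(F)c1`) has not yet been measured. It carries 3-fluorophenyl in place of 4-methoxyphenyl on a carbon with a double bond to nitrogen.

For the measured compounds named here, three measured steps bear on this change, each swapping one group on the aromatic ring: a 1.2-fold higher number from compound 1 to compound 2 (0.08 log units; within the scatter), a 1.0-fold lower number from compound 1 to compound 3 (0.02 log units; within the scatter) and a 1.2-fold lower number from compound 2 to compound 3 (0.09 log units; within the scatter). All three stay within the scatter. Going by the values given here, none of the measured compounds carries 3-fluorophenyl, however, so these steps are only indirect guidance, and a wider range is warranted. No shift beyond the scatter is expected in this assay.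

The expected change is a 1.1-fold higher number from compound 3 to compound 4 (0.03 log units; within the scatter).

For compound 4 the estimated value is 21000 nM, with an expected range from 11000 nM to 40000 nM.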

Compound 4, half-maximal inhibitory concentration: 27500 nM
The estimate for compound 4 lay 1.3-fold (0.12 log units) below the measured number, within the range that was stated.
By their numbers in this assay, from the lowest: compounds 3, 1, 2 and 4 (each within the scatter of the next).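

In this assay, putting 3-fluorophenyl on the carbon with a double bond to nitrogen gives steps that all stay within the scatter: (a 1.4-fold higher number from compound 3 to compound 4 (0.14 log units; within the scatter)), (a 1.1-fold higher number from compound 2 to compound 4 (0.05 log units; within the scatter)) and (a 1.3-fold higher number from compound 1 to compound 4 (0.13 log units; within the scatter)). The earlier compounds shown here showed this only for 4-chlorophenyl, 4-bromophenyl and 4-methoxyphenyl, and compound 4 extends it to a fluorine-bearing group with a different number in its name, so all four compounds remain indistinguishable in this read-out. No measurement here offers any explanation for this result.

Going by these compounds, whether an amine, a carboxylic acid or a longer chain in place of these rings would move the number beyond the scatter remains open. On these data alone, how 4-fluorophenyl would compare with 3-fluorophenyl also remains open, so the contribution of fluorine cannot be separated from that of its placement.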